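A few compounds are considered here, and "the series" means these few. Any claim that something is new, unique, unknown or untested is made for them only; others in the source may bear on it.

compound 1, `COc1ccc(/C=C/S(=O)(=O)Cc2ccc(OC)cc2)cc1`: in a functional assay on DU-145 cells (Homo sapiens) for antiproliferative activity, read by trypan blue exclusion (on this read-out lower numbers stand for stronger inhibition and higher numbers for weaker inhibition), compound 1 gives > 20000 nM, which is a limit of the assay
compound 2, `COc1ccc(CS(=O)(=O)/C=C/c2ccc(OC)c(OC)c2)cc1`: in this assay compound 2 gives > 20000 nM, again a limit of the assay
compound 3, `COc1ccc(CS(=O)(=O)/C=C/c2cc(OC)c(OC)cc2OC)cc1`: in this assay compound 3 gives > 20000 nM, once more a limit of the assay

Compound 2 thus stands at the limit, and so do the two other values shown (the limit of > 20000 nM in this assay, at which 3 of the 3 values shown sit). The step that the two limits leave unreadable from compound 1 to compound 2 cannot be read, and neither can the step that the two limits leave unreadable from compound 2 to compound 3, since both ends sit at the limit. Compound 4, `COc1ccc(CS(=O)(=O)/C=C/c2ccc(OC)c(OC)c2OC)cc1`, arises from compound 2 by methoxy in place of hydrogen on an aromatic carbon. The two measured steps that bear on this change, each a methoxy in place of hydrogen on an aromatic carbon, give no readable size and no direction, so nothing beyond the scatter can be expected in either direction. The step from compound 2 to compound 4 is therefore estimated as a number no higher from compound 2 to compound 4 (the limit leaves the size open). Compound 4 is expected to give about 20000 nM, within 6000 nM to 20000 nM, most likely again as a limit.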

Compound 4, half-maximal inhibitory concentration: > 20000 nM
Compound 4 ended at the assay's limit (the forecaster's own chance of this, stated with the estimate: 80%); the middle value sits exactly at the limit.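

No new step can be read from compound 4: like compound 2, it stands at a limit, and the step between them stays unreadable. In this assay, every compound shown sits at that limit: the limit of > 20000 nM in this assay, at which 4 of the 4 values shown sit. The compounds shown leave open what size or direction, if any, a methoxy in place of hydrogen on an aromatic carbon has on this read-out.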